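Adding Methyl to the Aromatic Nitrogen of Compound 3

This account rests on a few compounds, and the source may have more. Where it says the series, first, only, none or still open, it means among the compounds named here.

In a functional assay on A2780 cells (Homo sapiens) for antiproliferative activity, read by MTT assay, with a stated time of 48 h (a lower number here means a stronger inhibitor, a higher number a weaker inhibitor), compound 1 (`COc1ccc2c(/C=C(\C)C(=O)c3cc(OC)c(OC)c([Se]C)c3)cn(C)c2c1`) gives 26 nM and compound 2 (`COc1ccc2c(/C=C(\C)C(=O)c3cc(OC)c(OC)c([Se]C)c3)c[nH]c2c1`) gives 18 nM while compound 3 (`COc1cc(C(=O)/C(C)=C/c2c[nH]c3ccccc23)cc([Se]C)c1OC`) gives 25 nM so compound 3 lies within the scatter of both. Compound 4 (`COc1cc(C(=O)/C(C)=C/c2cn(C)c3ccccc23)cc([Se]C)c1OC`) carries methyl in place of hydrogen on an aromatic nitrogen. For the measured compounds named here, the one measured step at that nitrogen runs the opposite way, with hydrogen in place of methyl (a 1.4-fold lower number from compound 1 to compound 2 (0.16 log units; within the scatter)). The step that removes methoxy (a 1.4-fold higher number from compound 2 to compound 3 (0.14 log units; within the scatter)) concerns an aromatic carbon and bears on it only indirectly. Read in reverse, the nitrogen step suggests a slightly higher number at most. The expected change is a 1.3-fold higher number from compound 3 to compound 4 (0.11 log units; within the scatter) and so none beyond the scatter. Compound 4 is estimated at 32 nM with an expected range from 16 nM to 65 nM in this assay.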

Compound 4, half-maximal inhibitory concentration: 35 nM
Beside the measured number, compound 4's estimate is 1.1-fold (0.04 log units) below it; measured number inside the range.
By their numbers in this assay, from the lowest: compounds 2, 3, 1 and 4 (each within the scatter of the next).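

On the core without the methoxy, methyl in place of hydrogen on the aromatic nitrogen gives a 1.4-fold higher number from compound 3 to compound 4 (0.15 log units; within the scatter) in this assay and so stays within the scatter on a second core. The nitrogen change reads alike on both cores: the same change on two cores in this assay, a 1.4-fold lower number (0.16 log units; within the scatter) from compound 1 to compound 2 and a 1.4-fold lower number (0.15 log units; within the scatter) from compound 4 to compound 3, 1.0-fold (0.01 log units) apart, within the scatter of two such steps. With methyl on the nitrogen, hydrogen in place of methoxy gives a 1.3-fold higher number from compound 1 to compound 4 (0.13 log units; within the scatter) and matches its earlier step: the same change on two cores in this assay, a 1.4-fold higher number (0.14 log units; within the scatter) from compound 2 to compound 3 and a 1.3-fold higher number (0.13 log units; within the scatter) from compound 1 to compound 4, 1.0-fold (0.01 log units) apart, within the scatter of two such steps.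

The compounds shown carry only hydrogen or methyl on this nitrogen. They leave open how a longer chain, or a chain ending in an amine or a carboxylic acid, would read there.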